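This account rests on a few compounds, and the source may have more. Where it says the series, first, only, none or still open, it means among the compounds named here.

Of the compounds shown here, three built on one shared core have been measured in an ADME assay on MT4 cells (Homo sapiens) for cytotoxicity, read by MTT assay, with a stated time of 4 days; a lower number here means that less compound is tolerated, a higher number that more compound is tolerated: compound 1 `C/C(=N\NC(=O)COc1cccc2ccccc12)c1ccccc1Br`, compound 2 `C/C(=N\NC(=O)COc1cccc2ccccc12)c1ccc([N+](=O)[O-])cc1` and compound 3 `C/C(=N\NC(=O)COc1cccc2ccccc12)c1ccccc1O`. Compound 1 gives 79.8 ug/mL, compound 2 gives 89.3 ug/mL, and compound 3 gives 11.3 ug/mL, the lowest of the three numbers.

The next compound, compound 4 `C/C(=N\NC(=O)COc1cccc2ccccc12)c1ccc(O)cc1`, carries 4-hydroxyphenyl in place of 2-hydroxyphenyl on a carbon with a double bond to nitrogen. Going by the values given here, no measured step makes this exact swap, so the evidence is indirect. The step of a 1.1-fold higher number from compound 1 to compound 2 (0.05 log units; within the scatter) shows that 4-nitrophenyl in place of 2-bromophenyl stays within the scatter. Against that stand two larger steps, a 7.1-fold lower number from compound 1 to compound 3 (0.85 log units; beyond the scatter) and a 7.9-fold lower number from compound 2 to compound 3 (0.90 log units; beyond the scatter), both beyond the scatter. Among the compounds with values here, compound 3 is the only measured compound with a hydroxy group, so the data cannot separate the hydroxy group itself from 2-hydroxyphenyl in particular. Compound 4 keeps a hydroxy group but lacks 2-hydroxyphenyl, so a modest move towards a higher number is expected in this assay, probably not the whole way back to compound 1 at 79.8 ug/mL. The expected change is a 2.7-fold higher number from compound 3 to compound 4 (0.42 log units; beyond the scatter). For compound 4 the estimated value is 30 ug/mL, with an expected range from 9 ug/mL to 100 ug/mL.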

Compound 4, half-maximal cytotoxic concentration: 68.8 ug/mL
The estimate for compound 4 lay 2.3-fold (0.36 log units) below the measured number; low and high end bracket the measured number.
By their numbers in this assay, from the lowest: compound 3; then compounds 4, 1 and 2 (each within the scatter of the next).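

Moving the hydroxy group, with the atoms otherwise unchanged, turns 2-hydroxyphenyl into 4-hydroxyphenyl and gives (a 6.1-fold higher number from compound 3 to compound 4 (0.78 log units; beyond the scatter)) in this assay, so the earlier question is now answered: a hydroxy group alone does not bring the low number, which among these compounds belongs to 2-hydroxyphenyl. The new compound also stays level with the two compounds that carry no hydroxy group, with (a 1.3-fold lower number from compound 2 to compound 4 (0.11 log units; within the scatter)) and (a 1.2-fold lower number from compound 1 to compound 4 (0.06 log units; within the scatter)), which leaves compound 3 as the only one of the four set apart from the others. Nothing measured here explains why the place of the hydroxy group on the ring matters so much.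

Still open, from the compounds shown here alone, is whether the low number needs the hydroxy group itself, since 2-aminophenyl or 2-methoxyphenyl, with an amine or a methoxy group in place of the hydroxy group, would test this directly. Also open, going by these compounds, is whether the effect of 2-hydroxyphenyl holds when the rest of the shared core changes, for example with a longer chain in place of the one that links the amide carbonyl to its ether oxygen.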